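The compounds below may be only part of what the source reports. "The series", "measured", "known", "first", "only" and "open" are said of these compounds alone.

Of the compounds shown here, two sharing one core have been measured in a functional assay on the whole organism for inhibition, with Rattus norvegicus as the target, read by paw edema, with a stated time of 3 h, at a dose of 100 mg/kg by the oral route; a lower number here means less inhibition, a higher number more inhibition at the dose given (going by the name of the read-out). Compound 1 `CCCCCCCCc1nc2ccc(Cl)cc2nc1CCCCCCCC(=O)O` gives 26.7% in this assay, and compound 2 `CCCCCCCCc1nc2ccc([N+](=O)[O-])cc2nc1CCCCCCCC(=O)O` gives 39.6% in this assay. Among the compounds with values here, the single change between them is a number 12.9 percentage points higher from compound 1 to compound 2 (beyond the scatter). Compound 2 therefore stands highest of the two numbers, with compound 1 the nearest and lower beyond the scatter.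

Compound 3 `CCCCCCCCc1nc2ccccc2nc1CCCCCCCC(=O)O` has not yet been measured in this assay. Compared with compound 2 it shows (hydrogen in place of nitro on an aromatic carbon). Within the data shown here, only one measured step bears on this change, a number 12.9 percentage points higher from compound 1 to compound 2 (beyond the scatter), a modest rise that accompanied the arrival of the nitro group. Here the nitro group departs and nothing else changes, so a modest fall in this assay is expected, though no measured pair sets hydrogen against nitro directly. Compound 3 is expected to give 27%, within a range from 12% to 42%. The estimated step is a number 12.6 percentage points lower from compound 2 to compound 3 (beyond the scatter).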

Compound 3, a percentage reported as inhibition, in the whole organism at one dose (the size of the read-out at that dose, not a potency): 34.4%
Compound 3: middle estimate off by 7.4 percentage points, on the low side, and the stated range covers the measured number.
By their numbers in this assay, from the lowest: compounds 1, 3 and 2 (each within the scatter of the next, the first and the last beyond it).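

In this assay, hydrogen in place of nitro gives a number 5.2 percentage points lower from compound 2 to compound 3 (within the scatter), and hydrogen in place of chloro gives a number 7.7 percentage points higher from compound 1 to compound 3 (within the scatter). Hydrogen on this aromatic carbon therefore cannot be told apart from either group, and only the direct change from chloro to nitro, a number 12.9 percentage points higher from compound 1 to compound 2 (beyond the scatter), stands clear of the usual scatter. The earlier step alone could not show this, since it lacked the compound carrying hydrogen as a reference. Nothing available here offers a reason for these numbers.

The compounds shown leave open whether an amine or a methoxy group on this same aromatic carbon would separate from hydrogen beyond the scatter. They also leave open how a methyl ester in place of the carboxylic acid would read in this assay.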